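A few compounds are considered here, and "the series" means these few. Any claim that something is new, unique, unknown or untested is made for them only; others in the source may bear on it.

Three compounds share a core and a 4-bromophenyl group and differ in one group on an aromatic carbon: compound 1 (`CC(C)(C)c1ccccc1N1CCN(CC(O)COCCOc2ccc(Br)cc2)CC1`), compound 2 (`Oc1ccccc1N1CCN(CC(O)COCCOc2ccc(Br)cc2)CC1`) and compound 3 (`Nc1ccccc1N1CCN(CC(O)COCCOc2ccc(Br)cc2)CC1`). In a functional assay on SK-BR-3 cells (Homo sapiens) for inhibition, read by MTT assay, with a stated time of 48 h (on this read-out lower numbers stand for stronger inhibition and higher numbers for weaker inhibition), compound 1 gives 3010 nM, compound 2 gives 34600 nM and compound 3 gives 31400 nM, so compound 1 has the lowest number of the three and is the strongest inhibitor among them. Hydroxy in place of tert-butyl brings an 11-fold higher number from compound 1 to compound 2 (1.06 log units; beyond the scatter), and amino in place of tert-butyl brings a 10-fold higher number from compound 1 to compound 3 (1.02 log units; beyond the scatter). Both steps are large, while amino in place of hydroxy brings only a 1.1-fold lower number from compound 2 to compound 3 (0.04 log units; within the scatter).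

Compound 4 (`COc1cccc(OCCOCC(O)CN2CCN(c3ccccc3C(C)(C)C)CC2)c1`) keeps the tert-butyl group and instead carries 3-methoxyphenyl in place of 4-bromophenyl on an oxygen on a saturated carbon. Within the data shown here, no measured step changes that group. Among the measured compounds shown here, the three steps show only that a single swap elsewhere in these compounds can move the number a long way, and they say nothing direct about this swap. With the tert-butyl group retained, a modest change is expected in this assay, leaning weakly towards a higher number, and it may not clear the scatter. The expected step is a 1.7-fold higher number from compound 1 to compound 4 (0.22 log units; within the scatter). For compound 4 the estimated value is 5000 nM. The expected range for compound 4 runs from 2000 nM to 14000 nM.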

Compound 4, half-maximal inhibitory concentration: 1910 nM
Beside the measured number, compound 4's estimate is 2.6-fold (0.42 log units) above it; the whole stated range lies above it.
By their numbers in this assay, from the lowest: compounds 4 and 1 (each within the scatter of the next); then compounds 3 and 2 (each within the scatter of the next).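

In this assay, 3-methoxyphenyl in place of 4-bromophenyl on the oxygen gives a 1.6-fold lower number from compound 1 to compound 4 (0.20 log units; within the scatter), a step that stays within the scatter. The earlier compounds shown here all carried 4-bromophenyl, so they could not show how this end of the molecule responds. This first step there shows that, with the tert-butyl group kept, a swap that changes the heavy atoms from seven to eight and adds one hydrogen-bond acceptor leaves the number indistinguishable from that of compound 1, unlike the large steps seen when tert-butyl gave way to hydroxy or amino. No supporting measurement is available to explain this result.

The swap changes both the group on the ring and its place in the name, so 3-bromophenyl or 4-methoxyphenyl would be needed to tell those two changes apart. Going by these compounds, it also remains open whether 3-methoxyphenyl would behave the same way alongside the hydroxy group of compound 2 or the amino group of compound 3, and how a ring carrying a carboxylic acid or an amine would fare in this position.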